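Fluoro-methylphenyl amide variant of a flavonol series

The source may hold more compounds than are shown below. What is called first, only, known or untested is meant among the compounds shown, and "the series" means these compounds.

Measured compounds:
compound 1, `Cc1cccc(C(=O)Nc2cccc(-c3oc4cc(-c5ccc(F)cc5)ccc4c(=O)c3O)c2)c1`, 7850 nM
compound 2, `CCc1ccc(C(=O)Nc2cccc(-c3oc4cc(-c5ccc(F)cc5)ccc4c(=O)c3O)c2)cc1`, 22800 nM

Going by the values given here, compound 2 gives the higher of the two numbers in a functional assay on MCF7 cells (Homo sapiens) for antiproliferative activity, read by CCK-8 assay, with a stated time of 72 h (on this read-out lower numbers stand for stronger inhibition and higher numbers for weaker inhibition), and its only neighbour is compound 1, from which it is separated by a 2.9-fold higher number from compound 1 to compound 2 (0.46 log units; beyond the scatter). Compound 3, `Cc1cc(C(=O)Nc2cccc(-c3oc4cc(-c5ccc(F)cc5)ccc4c(=O)c3O)c2)ccc1F`, differs from compound 2 by 4-fluoro-3-methylphenyl in place of 4-ethylphenyl on a carbonyl carbon. Among the compounds with values here, the single measured step that bears on this change is the one from compound 1 to compound 2, where swapping one substituted phenyl for another on the carbonyl carbon moved the number by a modest amount. Compound 3 carries a 3-methyl group as compound 1 does, with a fluorine added, so its number is expected to fall back toward that of compound 1, a step of a 2.4-fold lower number from compound 2 to compound 3 (0.38 log units; beyond the scatter). Compound 3 is therefore estimated at 9500 nM, within a range of 3500 nM to 26000 nM.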

Compound 3, half-maximal inhibitory concentration: 7710 nM
Compound 3: middle estimate off by 1.2-fold (0.09 log units), on the high side; the range from low to high includes it.
By their numbers in this assay, from the lowest: compounds 3 and 1 (each within the scatter of the next); then compound 2.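

In this assay the step of a 3.0-fold lower number from compound 2 to compound 3 (0.47 log units; beyond the scatter) shows that 4-fluoro-3-methylphenyl on the carbonyl carbon does not share the higher number seen with 4-ethylphenyl. Going by these compounds alone, the step of a 1.0-fold lower number from compound 1 to compound 3 (0.01 log units; within the scatter) gives the first reading of fluoro in place of hydrogen on an aromatic carbon, and it leaves the two numbers within the scatter of each other. Nothing measured here explains either result.

Compound 2 alone carries 4-ethylphenyl, so the compounds shown cannot tell whether its higher number goes with the ethyl group itself or with where the substituent stands on the ring. Also open, on these data alone, is how a chloro group, a dimethylamino group or a carboxylic acid on this phenyl would read, and whether fluoro would leave the number as little moved on a phenyl without the methyl group.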